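Removing the chloro group from the 2-chloro-6-fluorophenyl sulfide

The compounds below may be only part of what the source reports. "The series", "measured", "known", "first", "only" and "open" are said of these compounds alone.

Of the compounds shown here, three have been measured in an assay on isolated protein for binding affinity to Equilibrative nucleoside transporter 1 (Homo sapiens); a lower number here means a stronger inhibitor, a higher number a weaker inhibitor. Compound 1 `Cc1cccc(CSc2ncnc3c2ncn3[C@@H]2O[C@H](CO)[C@@H](O)[C@H]2O)c1` gives 12000 nM. Among the measured compounds shown here, compound 2 `OC[C@H]1O[C@@H](n2cnc3c(CSc4ccccc4Br)ncnc32)[C@H](O)[C@@H]1O` gives 2400 nM, and the step of a 5.0-fold lower number from compound 1 to compound 2 (0.70 log units; beyond the scatter) is the one clear change in the set. Compound 3 `OC[C@H]1O[C@@H](n2cnc3c(CSc4c(F)cccc4Cl)ncnc32)[C@H](O)[C@@H]1O` gives 1510 nM; the step of a 1.6-fold lower number from compound 2 to compound 3 (0.20 log units; within the scatter) does not separate compound 3 from compound 2, while compound 3 sits well apart from compound 1.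

Compound 4 `OC[C@H]1O[C@@H](n2cnc3c(CSc4ccccc4F)ncnc32)[C@H](O)[C@@H]1O` differs from compound 3 by hydrogen in place of chloro on an aromatic carbon, ortho to a large group and meta to a fluoro group; cut one bond further out, the change reads 2-chloro-6-fluorophenyl to 2-fluorophenyl. For the measured compounds named here, the only measured step that touches the substitution of this ring is a 1.6-fold lower number from compound 2 to compound 3 (0.20 log units; within the scatter), which swaps one halogen pattern for another and stays within the scatter. Going by the values given here, no measured step removes a halogen outright, and the step of a 5.0-fold lower number from compound 1 to compound 2 (0.70 log units; beyond the scatter) concerns a different part of the molecule. Compound 4 is therefore expected to lose a little, with a 1.9-fold higher number from compound 3 to compound 4 (0.27 log units; within the scatter). The estimate for compound 4 in this assay is 2800 nM, with a range from 1100 nM to 7000 nM.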

Compound 4, half-maximal inhibitory concentration: 355 nM
The estimate for compound 4 lay 7.9-fold (0.90 log units) above the measured number; measured number below the stated range.
By their numbers in this assay, from the lowest: compound 4; then compounds 3 and 2 (each within the scatter of the next); then compound 1.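

Among the compounds shown here, in (this assay), the aromatic carbon that carried the chloro group is the first place on this ring where a single change is clearly read: hydrogen in place of chloro gives (a 4.3-fold lower number from compound 3 to compound 4 (0.63 log units; beyond the scatter)), whereas the earlier change of halogen pattern stayed within the scatter (a 1.6-fold lower number from compound 2 to compound 3 (0.20 log units; within the scatter)). With one halogen left on the ring, fluoro in place of bromo also separates clearly (a 6.8-fold lower number from compound 2 to compound 4 (0.83 log units; beyond the scatter)), and the step from the 3-methylbenzyl sulfide is now large (a 34-fold lower number from compound 1 to compound 4 (1.53 log units; beyond the scatter)), which leaves compound 4 as the strongest inhibitor of the four, on this small set only. Nothing at hand bears on the reason for the gain on losing the chloro group.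

On these data alone, whether the remaining fluoro group contributes to the value of compound 4 stays open, since a plain phenyl sulfide would be needed to read that step. Equally open, as far as these compounds go, is how a methoxy group or an amine at the fluoro-bearing carbon would compare with the 2-fluorophenyl sulfide, and whether this order of halogens holds on other parts of the series.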